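The source may hold more compounds than are shown below. What is called first, only, known or untested is meant among the compounds shown, and "the series" means these compounds.

Compound 1, `CNC(=O)c1cc(Oc2ccc3nc(Nc4ccccc4)ncc3c2)ccn1`: in an ADME assay on Caco-2 cells (Homo sapiens) for permeability, in the apical to basolateral direction (on this read-out lower numbers stand for lower permeability and higher numbers for higher permeability), compound 1 gives < 1 10^-6 cm/s, which is a limit of the assay rather than a number.
Compound 2, `CNC(=O)c1cc(Oc2ccc3nc(Nc4cccc(C(F)(F)F)c4)ncc3c2)ccn1`: in this assay compound 2 gives < 1 10^-6 cm/s, again a limit of the assay.
Compound 3, `CNC(=O)c1cc(Oc2ccc3nc(Nc4ccc(F)cc4)ncc3c2)ccn1`: in this assay compound 3 gives < 1 10^-6 cm/s, also a limit of the assay.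

Compound 3 therefore stands where every measured compound of this set stands, at the floor of what this assay can report, as shown by the limit of < 1 10^-6 cm/s in this assay, at which 3 of the 3 values shown sit. The three steps between the measured compounds, a step that the two limits leave unreadable from compound 1 to compound 2, a step that the two limits leave unreadable from compound 1 to compound 3 and a step that the two limits leave unreadable from compound 2 to compound 3, have a limit at both ends, so none of them has a readable size, and none of them can say whether a change on this ring moves the read-out.

Compound 4, `CNC(=O)c1cc(Oc2ccc3nc(Nc4ccc(OC)cc4)ncc3c2)ccn1`, has not yet been measured. It differs from compound 3 by methoxy in place of fluoro on an aromatic carbon. With no readable step among the measured compounds to lean on, the expectation is that compound 4 behaves like compound 3, with a step that the limit leaves unreadable from compound 3 to compound 4 expected to fall within the scatter. The estimate for compound 4 is 0.6 10^-6 cm/s, with a range from 0.2 10^-6 cm/s to 2 10^-6 cm/s, and most likely again only a limit.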

Compound 4, apparent permeability: < 1 10^-6 cm/s
Compound 4 was reported as a limit; the forecaster's own chance of this, stated with the estimate: 75%; the middle value lies beyond the limit too.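

Compound 4 sits at the same limit as compound 1, compound 2 and compound 3, so none of its steps to those compounds can be read: the limit of < 1 10^-6 cm/s in this assay, at which 4 of the 4 values shown sit.

The compounds shown leave open what their true permeabilities are, and whether changing these groups moves the read-out at all.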